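The source may hold more compounds than are shown below. What is called first, only, known or untested is meant among the compounds shown, and "the series" means these compounds.

Measured so far in a functional assay on KM12 cells (Homo sapiens) for cytotoxicity, read by sulforhodamine B assay, with a stated time of 48 h, tested at 1 uM; a lower number here means a stronger effect, a higher number a weaker effect of the compound at the concentration tested:
compound 1, `COc1cc(-c2cc(/C=C/C(=O)c3ccc(Cl)c(Cl)c3)[nH]n2)cc(OC)c1OC`: 85%
compound 2, `COc1ccc(-c2cc(/C=C/C(=O)c3cc(OC)c(OC)c(OC)c3)[nH]n2)cc1OC`: 45%
compound 3, `COc1ccc(-c2cc(/C=C/C(=O)c3ccc(N)cc3)[nH]n2)cc1`: 77%

Compound 1 gives the largest of the three numbers. The number for compound 3 lies within the usual scatter of the number for compound 1, so the two cannot be told apart. Going by the values given here, compound 2 lies well below compound 1, beyond the scatter, and is the only compound here with a clearly stronger effect.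

Compound 4, `COc1ccc(C(=O)/C=C/c2cc(-c3cc(OC)c(OC)c(OC)c3)n[nH]2)cc1OC`, is still to be measured in this assay. It differs from compound 1 in one place: 3,4-dimethoxyphenyl in place of 3,4-dichlorophenyl on a carbonyl carbon. Among the compounds with values here, no pair of measured compounds differs in exactly this way, so the size of the step cannot be taken from a measured example. Compound 2, which carries methoxy groups rather than chlorine on both rings, gives the lowest number of the three, which hints that the change may move the number downward. For compound 4 a moderate decrease of the number is expected, a step of a number 20 percentage points lower from compound 1 to compound 4 (beyond the scatter), with wide uncertainty. Compound 4 is thus estimated at 65%, within a range from 40% to 90%.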

Compound 4, a percentage reported as activity, at one concentration (the size of the read-out at that concentration, not a potency): 54%
The estimate for compound 4 lay 11 percentage points above the measured number, and the stated range covers the measured number.
By their numbers in this assay, from the lowest: compounds 2 and 4 (each within the scatter of the next); then compounds 3 and 1 (each within the scatter of the next).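

In this assay, 3,4-dimethoxyphenyl in place of 3,4-dichlorophenyl on a carbonyl carbon gives a number 31 percentage points lower from compound 1 to compound 4 (beyond the scatter). This is the first change in one place among the compounds shown, and it establishes that the group on this carbonyl carbon can by itself move the number by a clear margin while the rest of compound 1 stays fixed. No measurement at hand explains the step.

It remains open whether both methoxy groups are needed, as a phenyl carrying a single methoxy group and an unsubstituted phenyl are not among the compounds shown. As far as these compounds go, how this position responds to ethoxy groups, an amine or a carboxylic acid on the same ring, with the rest of compound 1 unchanged, also remains open.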